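Fluoro to Methoxy on a Saturated Chain

This account rests on a few compounds, and the source may have more. Where it says the series, first, only, none or still open, it means among the compounds named here.

In a functional assay on HeLa cells (Homo sapiens) for cytotoxicity, read by WST assay, with a stated time of 48 h (on this read-out higher numbers stand for weaker inhibition and lower numbers for stronger inhibition), compound 2 `COc1cc(C(c2ccc(O)c(OC)c2)[C@@H](C)[C@H](C)CF)ccc1O` gives 37000 nM and compound 1 `COC[C@@H](C(C)C)C(c1ccc(O)c(OC)c1)c1ccc(O)c(OC)c1` gives 69000 nM in the same test. Among the compounds with values here, these are the only two numbers so far, and they lie within the usual scatter of each other, so the two compounds cannot be told apart.

Compound 3 `COC[C@@H](C)[C@H](C)C(c1ccc(O)c(OC)c1)c1ccc(O)c(OC)c1` comes from compound 2 through one change methoxy in place of fluoro on a saturated chain carbon, four bonds along the chain from two aromatic carbons so that fluoromethyl becomes methoxymethyl.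

Within the data shown here, only one measured step bears on this: a 1.9-fold lower number from compound 1 to compound 2 (0.27 log units; within the scatter) and there a 1-(methoxymethyl)-2-methylpropyl group gave way to a 2-(fluoromethyl)-1-methylpropyl group. That step is small, and it altered more of the chain than the present swap does. So no shift beyond the scatter is expected, and the estimated step is a 1.4-fold higher number from compound 2 to compound 3 (0.13 log units; within the scatter) in this comparison.

For compound 3 the expected value is 50000 nM with 24000 nM and 100000 nM as the estimated ends of its range.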

Compound 3, half-maximal inhibitory concentration: 58000 nM
The estimate for compound 3 lay 1.2-fold (0.06 log units) below the measured number; the measured number falls inside the stated range.
By their numbers in this assay, from the lowest: compounds 2, 3 and 1 (each within the scatter of the next).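

In this assay, methoxy in place of fluoro at this place on the chain gives a 1.6-fold higher number from compound 2 to compound 3 (0.20 log units; within the scatter) and stays within the scatter, so the two groups cannot be told apart here, even though methoxy counts as a hydrogen-bond acceptor and fluoro does not. Rearranging the chain, with 2-(methoxymethyl)-1-methylpropyl in place of 1-(methoxymethyl)-2-methylpropyl, gives a 1.2-fold lower number from compound 1 to compound 3 (0.08 log units; within the scatter) and also stays within the scatter, so compound 3 cannot be told apart from compound 1 either. No measurement at hand offers an explanation for how close these numbers lie.

The compounds shown end this chain only in fluoromethyl or methoxymethyl, so it remains open whether an amine, a carboxylic acid or a longer chain at this place would shift the number beyond the scatter. Going by these compounds, whether changes on the shared core would do so also remains open.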